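Trimming the amide tail in a cholesterol transporter binding series

This account rests on a few compounds, and the source may have more. Where it says the series, first, only, none or still open, it means among the compounds named here.

Measured compounds:
- compound 1, `CC(C)(C)OC(=O)NCCCNC(=O)CN1CN(c2ccccc2)C2(CCN(C(=O)c3ccc(C4CCCCC4)cc3)CC2)C1=O`: 6000 nM
- compound 2, `CC(C)(C)OC(=O)NCCCCNC(=O)CN1CN(c2ccccc2)C2(CCN(C(=O)c3ccc(C4CCCCC4)cc3)CC2)C1=O`: 4600 nM
- compound 3, `CCOC(=O)C1CCCN(C(=O)CN2CN(c3ccccc3)C3(CCN(C(=O)c4ccc(C5CCCCC5)cc4)CC3)C2=O)C1`: 4200 nM

The three measured compounds share one core and differ only in the group attached to the amide carbonyl of the side chain. In an assay on HEK293 cells for displacement of a labelled ligand from NPC1-like intracellular cholesterol transporter 1 (Homo sapiens) (a higher number here means a weaker inhibitor, a lower number a stronger inhibitor), compound 3 gives 4200 nM, the lowest of the three numbers, but its gap to the other two is small: compound 2 gives 4600 nM and compound 1 gives 6000 nM, both within the scatter of compound 3.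

Compound 4, `O=C(CN1CN(c2ccccc2)C2(CCN(C(=O)c3ccc(C4CCCCC4)cc3)CC2)C1=O)NCO`, carries the change ((hydroxymethyl)amino in place of 3-(ethoxycarbonyl)piperidin-1-yl on a carbonyl carbon). For the measured compounds named here, two measured steps touch the same place. The step of a 1.3-fold lower number from compound 1 to compound 2 (0.12 log units; within the scatter) and the step of a 1.4-fold lower number from compound 1 to compound 3 (0.15 log units; within the scatter) both altered this tail without moving the number beyond the scatter. On that basis the step of a 1.2-fold higher number from compound 3 to compound 4 (0.08 log units; within the scatter) is expected to be small as well, with no clear direction. Compound 4 is therefore estimated at 5000 nM in this assay, within a range of 2000 nM to 15000 nM.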

Compound 4, half-maximal inhibitory concentration: 8300 nM
Beside the measured number, compound 4's estimate is 1.7-fold (0.22 log units) below it, and the stated range covers the measured number.
By their numbers in this assay, from the lowest: compounds 3, 2, 1 and 4 (each within the scatter of the next).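

On a carbonyl carbon, (hydroxymethyl)amino with 3 heavy atoms and no ring replaces 3-(ethoxycarbonyl)piperidin-1-yl with 11 heavy atoms and one ring, and the result in this assay is a 2.0-fold higher number from compound 3 to compound 4 (0.30 log units; within the scatter) even though most of the group is gone. The two open-chain tails carrying tert-butoxycarbonyl give the same picture, with a 1.8-fold higher number from compound 2 to compound 4 (0.26 log units; within the scatter) and a 1.4-fold higher number from compound 1 to compound 4 (0.14 log units; within the scatter) as the other steps to this small group. So even this large cut in size, which also adds hydrogen-bond donors, gives no change that can be told from the scatter, and nothing measured here offers a reason.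

Still open, going by these compounds, is whether a simple amine or a carboxylic acid on this carbonyl carbon would move the number beyond the scatter.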